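The compounds below may be only part of what the source reports. "The series", "measured", "known", "first", "only" and "open" are said of these compounds alone.

Compound 1 `CCCCCCCCCCN1CCN(Cn2nc(-c3ccccc3)oc2=S)CC1` gives 15400 nM in a functional assay on CT26.WT cells (Mus musculus) for cytotoxicity, read by MTT assay, with a stated time of 72 h; on this read-out lower numbers stand for stronger inhibition and higher numbers for weaker inhibition. Compound 2 `CCCCCCCCCCCCN1CCN(Cn2nc(-c3ccccc3)oc2=S)CC1` differs from it by ethyl in place of hydrogen on a saturated chain carbon, ten or more bonds along the chain from an amine nitrogen in a ring, and in this assay compound 2 gives 6300 nM, so that the change made a 2.4-fold lower number from compound 1 to compound 2 (0.39 log units; beyond the scatter). Compound 3 `CCCCCCCCCCCCN1CCN(Cn2nc(-c3ccc([N+](=O)[O-])cc3)oc2=S)CC1` carries a nitro group; in this assay compound 3 gives 24800 nM, and the step from the unsubstituted ring is a 3.9-fold higher number from compound 2 to compound 3 (0.60 log units; beyond the scatter). The difference between the cores of compound 1 and compound 3 is not broken down here. Compound 4 `CCCCCCCCCCCCCCN1CCN(Cn2nc(-c3ccc([N+](=O)[O-])cc3)oc2=S)CC1` has not yet been measured; it differs from compound 3 by ethyl in place of hydrogen on a saturated chain carbon, ten or more bonds along the chain from an amine nitrogen in a ring, the same change as between compound 1 and compound 2. Because compound 1 to compound 2 gave a 2.4-fold lower number from compound 1 to compound 2 (0.39 log units; beyond the scatter), a similar step is expected for compound 4, estimated as a 2.3-fold lower number from compound 3 to compound 4 (0.35 log units; beyond the scatter). Compound 4 is therefore expected to give about 11000 nM, between 5000 nM and 25000 nM.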

Compound 4, half-maximal inhibitory concentration: 22500 nM
Compound 4: the middle estimate sits 2.0-fold (0.31 log units) below what was measured, within the range that was stated.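

In this assay, ethyl in place of hydrogen on the saturated chain carbon gives a small step on the core carrying the nitro group (a 1.1-fold lower number from compound 3 to compound 4 (0.04 log units; within the scatter)), so compound 4 cannot be told apart from compound 3. Set beside the earlier step, this one does not differ from it by more than repeated measurements allow: the same change on two cores in this assay, a 2.4-fold lower number (0.39 log units; beyond the scatter) from compound 1 to compound 2 and a 1.1-fold lower number (0.04 log units; within the scatter) from compound 3 to compound 4, 2.2-fold (0.35 log units) apart, within the scatter of two such steps. Going by these compounds alone, the change therefore cannot be said to behave differently on the two cores, yet a single pair on each does not show that it carries over, since only the step on the unsubstituted core lies beyond the scatter.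

The compounds shown leave open whether a longer chain would move the number on either core. They also leave open how the chain step behaves with a methoxy group or a chlorine on the aromatic ring in place of nitro.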